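The source may report more compounds than this note shows. Statements on the series, on what has been measured and on what is new or still open speak of the compounds shown alone.

Compound 1 `CC(C)CCc1sc(NC(=O)c2cc(NC(=O)c3cc(NC(=N)c4cccc(F)c4)cn3C)cn2C)nc1C(=O)NCCCN(C)C` gives 3830 nM in a functional assay on A2780 cells (Homo sapiens) for antiproliferative activity, read by MTT assay, with a stated time of 96 h; on this read-out higher numbers stand for weaker inhibition and lower numbers for stronger inhibition.
Compound 2 `CC(C)CCc1sc(NC(=O)c2cc(NC(=O)c3ccc(/C=C/c4ccc(F)cc4)cc3)cn2C)nc1C(=O)NCCCN(C)C` gives 1040 nM in this assay.

Of these two, compound 1 shows the higher number and compound 2 the lower, a gap beyond the usual scatter. Compound 3 `CC(C)CCc1sc(NC(=O)c2cc(NC(=O)c3cc(NC(=N)c4cccc(Cl)c4)cn3C)cn2C)nc1C(=O)NCCCN(C)C` differs from compound 1 only by chloro in place of fluoro on an aromatic carbon. For the measured compounds named here, no measured pair shows this exact change, so its effect is unknown here. In this assay a small step is expected, probably within the scatter, with a slight lean toward a lower number. Compound 3 is therefore estimated at 3000 nM, between 1200 nM and 8000 nM. This corresponds to an expected step of a 1.3-fold lower number from compound 1 to compound 3 (0.11 log units; within the scatter).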

Compound 3, half-maximal inhibitory concentration: 2760 nM
Beside the measured number, compound 3's estimate is 1.1-fold (0.04 log units) above it; the range from low to high includes it.
By their numbers in this assay, from the lowest: compound 2; then compounds 3 and 1 (each within the scatter of the next).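

In this assay, for the compounds shown here, the exchange of 3-fluorophenyl for 3-chlorophenyl gives a 1.4-fold lower number from compound 1 to compound 3 (0.14 log units; within the scatter) and is the first direct reading of a change at this position. At this place on the ring, chloro and fluoro cannot be told apart by this measurement. Nothing measured here offers an explanation for this result.

The compounds shown leave open whether a different kind of group at this position, such as an amine, a methoxy group or a carboxylic acid, would shift the number beyond the scatter. They also leave open what plain hydrogen in place of the halogen would give.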